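The source may hold more compounds than are shown below. What is called first, only, known or untested is meant among the compounds shown, and "the series" means these compounds.

Of the compounds shown here, three have so far been measured in a functional assay (CCRF-CEM cells, Homo sapiens), read by cell counting, with a stated time of 72 h; on this read-out higher numbers stand for weaker inhibition and lower numbers for stronger inhibition. Compound 1 `N#Cc1ncn(C/C=C2\OC(=O)C(OCc3ccccc3)=C2OCc2ccccc2)c1C#N` gives 7300 nM in this assay. Compound 2 `NC(=O)c1ncn(CCC2(O)NC(=O)C(OCc3ccccc3)=C2OCc2ccccc2)n1` gives 445000 nM in this assay, which is the higher of the two numbers obtained. The gap between compound 2 and compound 1 lies well beyond the usual scatter of repeated measurements. Compound 3 `COC(=O)c1ncn(C[C@H](O)[C@H]2OC(=O)C(OCc3ccccc3)=C2OCc2ccccc2)n1` returns only a limit of this assay, > 100000 nM, and not a number. That reading belongs to the limit of > 100000 nM in this assay, at which 1 of the 3 values shown sits.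

Compound 4 `NC(=O)c1ncn(CCC2(O)NC(=O)C(OCc3ccccc3)=C2OCc2ccccc2)c1C(N)=O` has not yet been measured. It differs from compound 2 in a single place: 4,5-dicarbamoyl-1H-imidazol-1-yl in place of 3-carbamoyl-1H-1,2,4-triazol-1-yl on a saturated chain carbon, two bonds along the chain from a saturated ring carbon. Within the data shown here, no measured pair shows this exchange on its own, and compound 1 and compound 3 differ from compound 2 in several places at once, so no size of step can be read off from the measured compounds. The expectation therefore stays close to compound 2, with a step of a 1.3-fold lower number from compound 2 to compound 4 (0.10 log units; within the scatter) that is expected to be no larger than the usual scatter, in no clear direction. On that basis compound 4 is estimated to give 350000 nM in this assay, with an expected range from 70000 nM to 1800000 nM.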

Compound 4, half-maximal inhibitory concentration: 154000 nM
The estimate for compound 4 lay 2.3-fold (0.36 log units) above the measured number; low and high end bracket the measured number.
By their numbers in this assay, from the lowest: compound 1; then compound 4; then compound 2.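

In this assay, among these compounds, putting 4,5-dicarbamoyl-1H-imidazol-1-yl in place of 3-carbamoyl-1H-1,2,4-triazol-1-yl on a saturated chain carbon, two bonds along the chain from a saturated ring carbon, gives the first single change that can be read: a 2.9-fold lower number from compound 2 to compound 4 (0.46 log units; beyond the scatter). The step is modest, but it shows that this place accepts a larger group, with 11 heavy atoms instead of 8 and two carbamoyl groups instead of one, and that the inhibition gets somewhat stronger rather than being lost. Compound 3 still offers only a limit and not a number, and it differs from the other compounds in several places, so it adds nothing to this comparison: the limit of > 100000 nM in this assay, at which 1 of the 4 values shown sits.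

The change replaces the ring and adds a second carbamoyl together, and no compound shown separates the two, so it remains open which of them accounts for the step. From the compounds shown here alone, it is also open how this place would respond to a carboxylic acid or an amine in place of a carbamoyl, or to a longer chain between the shared core and the ring.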